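A few compounds are considered here, and "the series" means these few. Any claim that something is new, unique, unknown or untested is made for them only; others in the source may bear on it.

Compound 1, `Cc1cc2ccccc2nc1-c1cn(CCC(F)(F)C(F)(F)C(F)(F)C(F)(F)C(F)(F)C(F)(F)C(F)(F)C(F)(F)F)nn1`, was tested in a functional assay on HeLa cells (Homo sapiens) for cytotoxicity, read by MTT assay, with a stated time of 24 h; a lower number here means a stronger inhibitor, a higher number a weaker inhibitor. In this assay compound 1 gives > 100 ug/mL, which is a limit of the assay rather than a number. Compound 2, `CCc1cc2ccccc2nc1-c1cn(-c2ccc(F)cc2)nn1`, belongs to the same set. In this assay compound 2 gives > 100 ug/mL, again a limit of the assay and not a number. Compound 1 therefore stands at the limit of > 100 ug/mL in this assay, at which 2 of the 2 values shown sit, and nothing measured separates it from compound 2. Compound 3, `CCCCc1cc2ccccc2nc1-c1cn(CCC(F)(F)C(F)(F)C(F)(F)C(F)(F)C(F)(F)C(F)(F)C(F)(F)C(F)(F)F)nn1`, is not yet measured in this assay. It differs from compound 1 by propyl in place of hydrogen on a saturated chain carbon bound to an aromatic carbon. For the measured compounds named here, no measured pair here shows what such a change does in this assay. The expected step that the limit leaves unreadable from compound 1 to compound 3 is small, within the usual scatter and in no particular direction, because compound 1 sits at the limit of > 100 ug/mL in this assay, at which 2 of the 2 values shown sit. The estimate for compound 3 in this assay is 150 ug/mL, expected to fall between 40 ug/mL and 600 ug/mL, with a strong chance that only a limit is reported once more.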

Compound 3, half-maximal inhibitory concentration: 32.8 ug/mL
Estimate against measurement, compound 3: 4.6-fold (0.66 log units) above, and the stated range ends above it.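

Replacing hydrogen with propyl on a saturated chain carbon bound to an aromatic carbon, which turns methyl into butyl, gives in this assay an at least 3.0-fold lower number from compound 1 to compound 3 (0.48 log units; beyond the scatter). Going by these compounds, the true size of this step stays open on one side, because compound 1 has only a limit of the assay and not a number: the limit of > 100 ug/mL in this assay, at which 2 of the 3 values shown sit. For the compounds shown here, compound 3 is the first compound in the set to give a number in this assay, so this position is the first place where a single change is seen to move the read-out, and the shift lies beyond the scatter.

The compounds shown do not tell whether the number would keep falling with a longer chain such as hexyl, or whether butyl owes its effect to chain length rather than to the added carbons alone, as a branched isobutyl or a cyclopentyl group could test. They also leave open whether the same change would have any effect on the core of compound 2, which differs from compound 3 in more than one place, and what an amine or a carboxylic acid at the end of the chain would do.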